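Phenyl for 4-cyanobenzyl on the shared quinoline-free core

This account rests on a few compounds, and the source may have more. Where it says the series, first, only, none or still open, it means among the compounds named here.

Measured compounds:
Compound 1, `COc1cccc(CNCCCNc2ccnc3cc(-c4ccc(C(C)(C)C)cc4)ccc23)c1O`: 237 10^-6 cm/s
Compound 2, `COc1ccc(Oc2ccc3c(NCCCNCc4cccc(OC)c4O)ccnc3c2)cc1`: 317 10^-6 cm/s
Compound 3, `COc1cccc(CNCCCNc2ccnc3cc(Cc4ccc(C#N)cc4)ccc23)c1O`: 23 10^-6 cm/s

In an ADME assay for permeability, using PAMPA, with a stated time of 30 min, at pH 7.4 (a higher number here means that the compound crosses the layer faster, a lower number that the compound crosses the layer more slowly), compound 3 gives the lowest of the three numbers. Its step from compound 1 was a 10-fold lower number from compound 1 to compound 3 (1.01 log units; beyond the scatter), and from compound 2 it was a 14-fold lower number from compound 2 to compound 3 (1.14 log units; beyond the scatter), whereas between compound 1 and compound 2 there was only a 1.3-fold higher number from compound 1 to compound 2 (0.13 log units; within the scatter). Compound 4, `COc1cccc(CNCCCNc2ccnc3cc(-c4ccccc4)ccc23)c1O`, differs from compound 3 by phenyl in place of 4-cyanobenzyl on an aromatic carbon. The two large steps both concern this same position and both ran downward into the 4-cyanobenzyl, so removing it toward a directly attached aryl, as in compound 1, is expected to run the other way. For compound 4 the expected step is a 7.8-fold higher number from compound 3 to compound 4 (0.89 log units; beyond the scatter), giving an estimate of 180 10^-6 cm/s, within 80 10^-6 cm/s to 320 10^-6 cm/s.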

Compound 4, apparent permeability: 237 10^-6 cm/s
Compound 4: middle estimate off by 1.3-fold (0.12 log units), on the low side; the measured number falls inside the stated range.
By their numbers in this assay, from the lowest: compound 3; then compounds 1, 4 and 2 (each within the scatter of the next).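

In this assay the low number of compound 3 is now tied to one change at this aromatic carbon, since phenyl in place of 4-cyanobenzyl gives a large step (a 10-fold higher number from compound 3 to compound 4 (1.01 log units; beyond the scatter)). The plain phenyl stays within the scatter of both larger groups (no change at the digits printed from compound 1 to compound 4 (within the scatter); a 1.3-fold lower number from compound 2 to compound 4 (0.13 log units; within the scatter)), so only 4-cyanobenzyl stands apart among these four compounds. No measurement shown accounts for this. Still open, going by these compounds, is whether the step goes with the nitrile or the carbon link: benzyl and 4-cyanophenyl at this carbon would separate the two.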